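The source may hold more compounds than are shown below. What is called first, only, known or untested is meant among the compounds shown, and "the series" means these compounds.

In a functional assay on PC-3 cells (Homo sapiens) for antiproliferative activity, read by MTT assay, with a stated time of 48 h (on this read-out lower numbers stand for stronger inhibition and higher numbers for weaker inhibition), compound 1 `COc1cc(N(Cc2ccc(C)cc2)C(=O)CSc2nc3ccccc3s2)cc(OC)c1OC` gives > 80000 nM, which is a limit of the assay. Going by the values given here, compound 2 `COc1ccc(CN(C(=O)CSc2nc3ccccc3s2)c2cc(OC)c(OC)c(OC)c2)cc1Br` gives 16000 nM, the only actual number so far. Compound 3 `COc1ccc(CN(C(=O)CSc2nc3ccccc3s2)c2cc(OC)c(OC)c(OC)c2)cc1C(F)(F)F` carries trifluoromethyl in place of bromo on an aromatic carbon, ortho to a methoxy group: trifluoromethyl in place of bromo on an aromatic carbon. Among the compounds with values here, only one measured step bears on this, the exchange of 4-methylphenyl for 3-bromo-4-methoxyphenyl, which is an at least 5.0-fold lower number from compound 1 to compound 2 (0.69 log units; beyond the scatter). That step altered the same group but does not compare bromo with trifluoromethyl, so no change beyond the scatter is expected in this assay. The expected step is small: a 1.1-fold higher number from compound 2 to compound 3 (0.05 log units; within the scatter). Compound 3 is estimated at 18000 nM, within a range of 7000 nM to 50000 nM.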

Compound 3, half-maximal inhibitory concentration: > 80000 nM
Compound 3 gave a limit, no number; the forecaster's own chance of this, stated with the estimate: 20%; middle value at least 4.4-fold (0.64 log units) away from the limit.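

On this aromatic carbon, ortho to a methoxy group, the exchange is not neutral in this assay: trifluoromethyl in place of bromo gives an at least 5.0-fold higher number from compound 2 to compound 3 (0.69 log units; beyond the scatter). Keeping the methoxy group is therefore not enough on its own, and the measurable activity of compound 2 depends on which group sits at this place. The earlier step could not show this, since it changed the whole aromatic group at once.

Going by these compounds, the step between the other two compounds cannot be read, and the true size of the loss stays open, because the value of compound 3 is a limit: the limit of > 80000 nM in this assay, at which 2 of the 3 values shown sit. Whether chloro or a nitrile on this carbon would keep the activity of compound 2 also remains open.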